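The compounds below may be only part of what the source reports. "The series", "measured", "known", "first", "only" and "open" are said of these compounds alone.

Compound 1 `Cc1noc(-c2nc(C)c3c(c2N)C(=O)N(Cc2ccc(-n4cccn4)cc2)C3=O)n1`, compound 2 `COc1ccccc1CN1C(=O)c2c(C)nc(-c3nc(C)no3)c(N)c2C1=O` and compound 3 `Cc1noc(-c2nc(C)c3c(c2N)C(=O)N(Cc2ccc(Cl)cn2)C3=O)n1` share one core and differ in the group on a saturated chain carbon bound to an amide-type nitrogen in a ring. In a physicochemical assay for solubility, using the shake flask method, in simulated intestinal fluid, measured as kinetic solubility, with a stated time of 2 h, at 25 degrees C, at pH 6.5 (a lower number here means a less soluble compound, a higher number a more soluble compound), compound 1 gives < 5000 nM, which is a limit and not a number. Compound 2 gives < 5000 nM, again a limit. Compound 3 also stands only at a limit, < 5000 nM. Going by the values given here, the series so far shows (the limit of < 5000 nM in this assay, at which 3 of the 3 values shown sit).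

Compound 4 `Cc1noc(-c2nc(C)c3c(c2N)C(=O)N(Cc2ccc(S(C)(=O)=O)cc2)C3=O)n1` carries 4-(methylsulfonyl)phenyl in place of 5-chloropyridin-2-yl at that same place (4-(methylsulfonyl)phenyl in place of 5-chloropyridin-2-yl on a saturated chain carbon bound to an amide-type nitrogen in a ring). Among the compounds with values here, the one measured step at this place is a step that the two limits leave unreadable from compound 2 to compound 3, so it offers no size or direction to carry over. No change beyond the usual scatter is therefore expected in this assay. The expected move is a step that the limit leaves unreadable from compound 3 to compound 4. Another limit is the most likely report. For compound 4 the estimated value is 3000 nM, with an expected range from 800 nM to 9000 nM.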

Compound 4, solubility: < 5000 nM
Compound 4: only a limit was reported; the forecaster's own chance of this, stated with the estimate: 80%; the middle value does not contradict the limit.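

In this assay compound 4 gives < 5000 nM, which is a limit and not a number. Its steps from compound 1, compound 2 and compound 3 therefore cannot be read. The compounds shown leave open how far apart these four truly lie, since all share one limit: the limit of < 5000 nM in this assay, at which 4 of the 4 values shown sit.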